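The compounds below may be only part of what the source reports. "The series", "measured", "known", "first", "only" and "open" are said of these compounds alone.

Measured so far in a functional assay on the whole organism (blood) with Rattus norvegicus as the target, with stated times of 24 h and 1 h, at a dose of 5 mg/kg by the intraperitoneal route; on this read-out higher numbers stand for a stronger effect at the one dose given and lower numbers for a weaker effect:
compound 1, `COc1ccc(Cl)cc1C(=O)NCCC1CCN(S(=O)(=O)NC(=O)NC[C@H]2C[C@@H]3CC[C@@H]2O3)CC1`, gives 27%
compound 2, `CC(=O)NCCC1CCN(S(=O)(=O)NC(=O)NC[C@@H]2C[C@@H]3C=C[C@@H]2C3)CC1`, gives 18%
compound 3, `O=C(NC1CCCCC1)NS(=O)(=O)N1CCC(CCNC(=O)c2csnn2)CC1`, gives 19%

Compound 2 shows the smallest of these three numbers, yet the gap to compound 3 and even the gap to compound 1 both lie within the usual scatter of such measurements, so the three compounds cannot be separated on this read-out.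

The step now taken leads from compound 2 to compound 4, `O=C(NC[C@@H]1C[C@@H]2C=C[C@@H]1C2)NS(=O)(=O)N1CCC(CCNC(=O)c2cc(Cl)ccn2)CC1`. The change is 4-chloropyridin-2-yl in place of methyl on a carbonyl carbon, on the carbonyl carbon whose other neighbour is an amide-type nitrogen; the rest of the molecule is kept. Among the measured compounds shown here, no measured pair in this set differs in just one place, so no step size is known from data. Compound 1, which also carries an aromatic ring on that carbonyl, gives 27%, which is the only hint available. In this assay compound 4 is therefore expected to move by a number 7 percentage points higher from compound 2 to compound 4 (within the scatter), a step not beyond the scatter, and the estimate for compound 4 is 25%, within 10% to 40%.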

Compound 4, a percentage reported as activity, at one dose (the size of the read-out at that dose, not a potency): 32%
For compound 4 the middle estimate is 7 percentage points below the measured one; measured number inside the range.
By their numbers in this assay, from the lowest: compounds 2, 3, 1 and 4 (each within the scatter of the next, the first and the last beyond it).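

Among the compounds shown here, on this carbonyl carbon, 4-chloropyridin-2-yl in place of methyl gives in this assay a change of a number 14 percentage points higher from compound 2 to compound 4 (beyond the scatter) and so this is the first difference in the set that stands clear of the scatter and can be tied to a single place. The position therefore accepts a much larger aromatic group than methyl without loss of effect at this dose. Nothing measured here explains the gain.

Going by these compounds, whether the ring itself or its chlorine carries the gain remains open. A plain pyridin-2-yl or a phenyl on the same carbonyl would help to separate the two.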